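Amide aryl exchange on the pyrazole series: compound 4

The source may hold more compounds than are shown below. What is called first, only, known or untested is meant among the compounds shown, and "the series" means these compounds.

Measured so far:
- compound 1 `COc1cc(-c2nn(-c3ccc(NC(=O)c4ccc(Cl)c(C(F)(F)F)c4)cc3)cc2-c2ccncc2)ccc1Cl` gives 3150 nM in a functional assay on SK-MEL-2 cells (Homo sapiens) for antiproliferative activity, read by sulforhodamine B assay, with a stated time of 48 h; a lower number here means a stronger inhibitor, a higher number a weaker inhibitor
- compound 2 `O=C(Nc1ccc(-n2cc(-c3ccncc3)c(-c3ccc(Cl)c(O)c3)n2)cc1)c1ccc(Cl)c(Cl)c1` gives 4050 nM in this assay
- compound 3 `O=C(Nc1ccc(-n2cc(-c3ccncc3)c(-c3ccc(Cl)c(O)c3)n2)cc1)c1cc(Cl)cc(Cl)c1` gives 6910 nM in this assay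

Compound 3 has the highest number of the three. Its nearest neighbour is compound 2, which lies within the scatter of it; compound 1 lies beyond the scatter, at a lower number.

Compound 4 `O=C(Nc1ccc(-n2cc(-c3ccncc3)c(-c3ccc(Cl)c(O)c3)n2)cc1)c1ccc(Cl)c(C(F)(F)F)c1` is not yet measured. It differs from compound 3 in one place: 4-chloro-3-(trifluoromethyl)phenyl in place of 3,5-dichlorophenyl on a carbonyl carbon.

Within the data shown here, one measured step touches the same position. The step of a 1.7-fold higher number from compound 2 to compound 3 (0.23 log units; within the scatter) shows that moving the two chlorines on this aromatic ring changed little. Among the measured compounds shown here, compound 1 carries the 4-chloro-3-(trifluoromethyl)phenyl group that enters here, but differs from compound 4 elsewhere in the shared core, so no step is computed for that pair; its value and that of compound 3 are simply what they are.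

Given the small step already seen at this position, compound 4 is expected to stay near compound 3, with any movement tending toward a lower number, a 1.8-fold lower number from compound 3 to compound 4 (0.26 log units; within the scatter). The estimate for compound 4 in this assay is 3800 nM, with a range from 1500 nM to 9000 nM.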

Compound 4, half-maximal inhibitory concentration: 1580 nM
Estimate against measurement, compound 4: 2.4-fold (0.38 log units) above; the measured number falls inside the stated range.
By their numbers in this assay, from the lowest: compounds 4, 1, 2 and 3 (each within the scatter of the next, the first and the last beyond it).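

In this assay the aryl group on the carbonyl carbon now proves able to move the number: moving the two chlorines gave only a 1.7-fold higher number from compound 2 to compound 3 (0.23 log units; within the scatter) but the exchange of 3,5-dichlorophenyl for 4-chloro-3-(trifluoromethyl)phenyl gives a 4.4-fold lower number from compound 3 to compound 4 (0.64 log units; beyond the scatter) and this lies beyond the scatter. Among these compounds, the single group exchange of trifluoromethyl for chloro on an aromatic carbon gives a 2.6-fold lower number from compound 2 to compound 4 (0.41 log units; beyond the scatter) and is also beyond the scatter, so a change at this ring can be read even with the 4-chloro group kept in both compounds. On the other side of the shared core, hydrogen in place of methyl on an oxygen on an aromatic ring gives a 2.0-fold lower number from compound 1 to compound 4 (0.30 log units; within the scatter) and stays within the scatter, so with this amide aryl group the two forms are not told apart in this assay.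

No measurement at hand accounts for any of these steps. Still open, going by these compounds, is how a nitrile, an amine or a carboxylic acid would fare in place of the trifluoromethyl on this ring, and whether the trifluoromethyl step holds with other groups on the shared core.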